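From methyl to methoxy: a question of cell tolerance

The compounds below may be only part of what the source reports. "The series", "measured", "known", "first", "only" and "open" are said of these compounds alone.

compound 1 `CCCS(=O)(=O)N1CCC2(CC1)OOC1(CCCCCC1)OO2` gives > 100 ug/mL as a limit
compound 2 `Cc1ccc(S(=O)(=O)N2CCC3(CC2)OOC2(CCCCCC2)OO3)cc1` gives > 100 ug/mL as a limit

In a functional assay on Huh-7 cells (Homo sapiens) for cytotoxicity, read by MTT assay, with a stated time of 72 h (a higher number here means that more compound is tolerated, a lower number that less compound is tolerated), compound 2 gives > 100 ug/mL as its reading, and that is a limit of the assay, not a number. Compound 1 likewise gives > 100 ug/mL as a limit. Going by the values given here, the only measured step is a step that the two limits leave unreadable from compound 1 to compound 2 and it offers no size to carry forward. The evidence so far is the limit of > 100 ug/mL in this assay, at which 2 of the 2 values shown sit, and nothing more.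

Compound 3 `COc1ccc(S(=O)(=O)N2CCC3(CC2)OOC2(CCCCCC2)OO3)cc1` is compound 2 with a single change. That change is methoxy in place of methyl on an aromatic carbon and it puts methoxy in place of methyl on an aromatic carbon, para to a large group. Among the compounds with values here, no measured step has a readable size for this change. The expectation therefore rests on compound 2 with > 100 ug/mL as a limit. No step beyond the usual scatter is expected in this assay and another limit is likely. The estimated change is a step that the limit leaves unreadable from compound 2 to compound 3 for now. For compound 3 the expected value is 110 ug/mL with an estimated range from 50 ug/mL to 200 ug/mL in this read-out.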

Compound 3, half-maximal cytotoxic concentration: > 100 ug/mL
Compound 3: only a limit was reported; the forecaster's own chance of this, stated with the estimate: 75%; the middle value does not contradict the limit.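

In this assay compound 3 gives > 100 ug/mL, which is a limit and not a number. No step among compound 1, compound 2 and compound 3 can be read, since all three stop at the same limit: the limit of > 100 ug/mL in this assay, at which 3 of the 3 values shown sit.

The compounds shown leave open how much of each the cells tolerate, and whether propyl, 4-methylphenyl and 4-methoxyphenyl differ at all in this read-out.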